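The compounds below may be only part of what the source reports. "The series", "measured", "known", "first", "only" and "open" are said of these compounds alone.

Compound 1 `CSc1ccc(/C=C(\C(=O)c2ccc(Br)cc2)S(=O)(=O)c2ccc(C)cc2)cc1`: 1000 nM
Compound 2 `CSc1ccc(/C=C(\C(=O)c2ccc(Br)cc2)S(=O)(=O)Cc2ccc(F)cc2)cc1`: 50000 nM

In a functional assay on DU-145 cells (Homo sapiens) for inhibition, read by trypan blue exclusion, with a stated time of 96 h (on this read-out lower numbers stand for stronger inhibition of growth and higher numbers for weaker inhibition of growth), compound 1 gives 1000 nM, the lowest of the two numbers; compound 2 gives 50000 nM. Among the measured compounds shown here, the only measured step, a 50-fold higher number from compound 1 to compound 2 (1.70 log units; beyond the scatter), alters the group on the sulfonyl sulfur and so does not touch the place that is altered in compound 3 `Cc1ccc(S(=O)(=O)/C(=C/c2c[nH]c3ccc(Cl)cc23)C(=O)c2ccc(Br)cc2)cc1`. Compound 3 differs from compound 1 in this way: 5-chloro-1H-indol-3-yl in place of 4-(methylsulfanyl)phenyl on a double-bonded chain carbon bound to a double-bonded chain carbon. For the measured compounds named here, no measured step bears on this change, so the size and direction of the step in this assay cannot be read from the data, and the expectation stays near compound 1 with a wide range. Compound 3 is expected to give 1000 nM (range 150 nM to 7000 nM), which would mean no change at the digits printed from compound 1 to compound 3 (within the scatter).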

Compound 3, concentration for 50% growth inhibition: 10000 nM
For compound 3 the middle estimate is 10-fold (1.00 log units) below the measured one, and the stated range ends below it.
By their numbers in this assay, from the lowest: compound 1; then compound 3; then compound 2.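

In this assay, 5-chloro-1H-indol-3-yl in place of 4-(methylsulfanyl)phenyl gives a 10-fold higher number from compound 1 to compound 3 (1.00 log units; beyond the scatter) at this place. This shows that the group on the double-bonded chain carbon, and not only the group on the sulfonyl sulfur, can shift the number beyond the scatter. Nothing available accounts for this step.

The compounds shown leave open how much of the step goes with the chlorine and how much with the indole itself. A plain 1H-indol-3-yl or a 4-chlorophenyl at this place would separate the two.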